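The source may report more compounds than this note shows. Statements on the series, on what has been measured and on what is new or still open speak of the compounds shown alone.

- compound 1 `C=C1C(=O)O[C@H]2[C@H]1CC/C(COC(=O)CCC(=O)NCCCCCCNC(=O)Cn1cc(F)c(=O)[nH]c1=O)=C\CC[C@@]1(C)O[C@@H]21`: > 20000 nM (a limit)
- compound 2 `C=C1C(=O)O[C@H]2[C@H]1CC/C(Cn1cc(Cn3cc(F)c(=O)n(Cc4ccccc4)c3=O)nn1)=C\CC[C@@]1(C)O[C@@H]21`: 9160 nM
- compound 3 `C=C1C(=O)O[C@H]2[C@H]1CC/C(COC(=O)Cn1cc(F)c(=O)n(Cc3cccc(F)c3)c1=O)=C\CC[C@@]1(C)O[C@@H]21`: 2530 nM

In a functional assay on Bel-7402 cells (Homo sapiens) for antiproliferative activity, read by MTT assay, with a stated time of 72 h (on this read-out lower numbers stand for stronger inhibition and higher numbers for weaker inhibition), compound 3 gives 2530 nM, the lowest number of the set. Compound 2 stands higher at 9160 nM, a gap beyond the usual scatter. For compound 1 the assay reports only a limit, > 20000 nM, and not a number.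

The next compound is compound 4 `C=C1C(=O)O[C@H]2[C@H]1CC/C(COC(=O)Cn1cc(F)c(=O)n(CCC)c1=O)=C\CC[C@@]1(C)O[C@@H]21`. Its change from compound 3 is ethyl in place of 3-fluorophenyl on a saturated chain carbon bound to an aromatic nitrogen. Cut one bond further out, this reads 3-fluorobenzyl to propyl.

Within the data shown here, no two measured compounds differ in only one place, so no measured step guides this one directly. Among the measured compounds shown here, a modest move towards a higher number is expected in this assay, as compound 3 at 2530 nM holds the lowest number so far. The estimated change is a 1.8-fold higher number from compound 3 to compound 4 (0.25 log units; within the scatter). For compound 4 the expected value is 4500 nM, with an estimated range of 1800 nM to 12000 nM.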

Compound 4, half-maximal inhibitory concentration: 8580 nM
Estimate against measurement, compound 4: 1.9-fold (0.28 log units) below; measured number inside the range.
By their numbers in this assay, from the lowest: compound 3; then compounds 4 and 2 (each within the scatter of the next). At a limit, above all of these: compound 1.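

Among these compounds, this is the first comparison here in which only one place changes, and it shows that this position affects the result in this assay: putting ethyl in place of 3-fluorophenyl on a saturated chain carbon bound to an aromatic nitrogen gives a 3.4-fold higher number from compound 3 to compound 4 (0.53 log units; beyond the scatter). The rest of the molecule stays the same, so the weaker inhibition goes with this single change, in which an aromatic ring and a fluorine leave together and a ringless ethyl enters. Nothing given here explains why the number rises.

The compounds shown leave open whether the ring, the fluorine or both matter, as this one step changes them together. They also leave open how a longer chain such as hexyl, or a pyridine ring, would behave at this place.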